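Cytotoxicity across aryl variants on the ring nitrogen

The source may report more compounds than this note shows. Statements on the series, on what has been measured and on what is new or still open speak of the compounds shown alone.

In an ADME assay on THP-1 cells (Homo sapiens) for cytotoxicity (on this read-out lower numbers stand for higher toxicity in this test and higher numbers for lower toxicity in this test), compound 1 `COc1ccn2c(Nc3ccccc3F)c(-c3ccccn3)nc2c1` gives 5750 nM, compound 2 `COc1ccn2c(Nc3cc(F)cc(F)c3)c(-c3ccccn3)nc2c1` gives 4300 nM, and compound 3 `COc1ccn2c(Nc3cc(Cl)ccc3Cl)c(-c3ccccn3)nc2c1` gives 8930 nM. Compound 3 stands highest of the three, though a 1.6-fold higher number from compound 1 to compound 3 (0.19 log units; within the scatter) and a 1.3-fold lower number from compound 1 to compound 2 (0.13 log units; within the scatter) stay within the scatter, and only a 2.1-fold higher number from compound 2 to compound 3 (0.32 log units; beyond the scatter) goes beyond it. Compound 4 `COc1ccn2c(Nc3ccc(F)cn3)c(-c3ccccn3)nc2c1` differs from compound 3 by 5-fluoropyridin-2-yl in place of 2,5-dichlorophenyl on a nitrogen on an aromatic ring. For the measured compounds named here, no measured step exchanges a phenyl for a pyridinyl on a nitrogen on an aromatic ring; the three steps that bear on it are exchanges of one substituted phenyl for another at that place, and none moved this assay more than modestly. A step of similar size, if any, is therefore expected, a 1.5-fold lower number from compound 3 to compound 4 (0.17 log units; within the scatter). Compound 4 is expected at 6000 nM, with a range from 3000 nM to 12000 nM.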

Compound 4, half-maximal cytotoxic concentration: 16000 nM
The estimate for compound 4 lay 2.7-fold (0.43 log units) below the measured number; the whole stated range lies below it.
By their numbers in this assay, from the lowest: compounds 2, 1, 3 and 4 (each within the scatter of the next, the first and the last beyond it).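

In this assay, 5-fluoropyridin-2-yl, the only ring with a hetero atom at this place, separates from two phenyl variants, with a 3.7-fold higher number from compound 2 to compound 4 (0.57 log units; beyond the scatter) and a 2.8-fold higher number from compound 1 to compound 4 (0.44 log units; beyond the scatter), while a 1.8-fold higher number from compound 3 to compound 4 (0.25 log units; within the scatter) remains unresolved. Compound 4 therefore groups with compound 3 at the lower-toxicity end of this small set. No measured data bear on the origin of these steps.

As far as these compounds go, the ring hetero atom and the fluorine pattern change together here, so their separate contributions stay open. An unsubstituted pyridin-2-yl or a pyridin-2-yl bearing an amine would help separate them.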